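Trifluoromethyl for fluoro on the benzyl ring of a pyrazole acid series

This account rests on a few compounds, and the source may have more. Where it says the series, first, only, none or still open, it means among the compounds named here.

Compound 1 `O=C(O)c1nn(Cc2cc(Br)ccc2OCc2ccccc2)cc1F` is assessed in a functional assay on CHO-K1 cells for antagonist activity at prostaglandin E2 receptor EP1 subtype (Homo sapiens), read by FLIPR (a higher number here means a weaker inhibitor, a lower number a stronger inhibitor), where compound 1 gives 692 nM. Compound 2 `O=C(O)c1nn(Cc2cc(Br)ccc2OCc2ccccc2)cc1C(F)(F)F` carries a trifluoromethyl in place of the fluoro of compound 1 (trifluoromethyl in place of fluoro on an aromatic carbon). In this assay compound 2 gives < 2000 nM, which is a limit of the assay and not a number. The step that the limit leaves unreadable from compound 1 to compound 2 is therefore not readable, owing to the limit of < 2000 nM in this assay, at which 1 of the 3 values shown sits.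

Compound 3 `Cc1cc(C(=O)O)nn1Cc1cc(Br)ccc1OCc1ccc(F)cc1` differs from compound 1 in more than one place; how the two cores differ is not broken down here. In this assay compound 3 gives 11.8 nM, the lowest of the two numbers in the set, below compound 1 by a margin beyond the usual scatter.

Compound 4 `Cc1cc(C(=O)O)nn1Cc1cc(Br)ccc1OCc1ccc(C(F)(F)F)cc1` is not yet measured. It carries a trifluoromethyl in place of fluoro (trifluoromethyl in place of fluoro on an aromatic carbon), the same kind of change as that from compound 1 to compound 2, but not the same: there the group sat on a five-membered aromatic ring with 2 nitrogen, next to the ring atom that bears a carboxy group, whereas here it sits on a six-membered aromatic ring of carbon only, para to a large group. Since a step that the limit leaves unreadable from compound 1 to compound 2 gives no readable size, the expectation for compound 4 rests on compound 3 at 11.8 nM with a step expected to stay near the scatter, a 1.7-fold higher number from compound 3 to compound 4 (0.23 log units; within the scatter). For compound 4 the estimate in this assay is 20 nM, expected to fall between 6 nM and 70 nM.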

Compound 4, inhibition constant: 97.7 nM
Compound 4: middle estimate off by 4.9-fold (0.69 log units), on the low side, and the stated range ends below it.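

In this assay, trifluoromethyl in place of fluoro on an aromatic carbon of a six-membered aromatic ring of carbon only, para to a large group, gives an 8.3-fold higher number from compound 3 to compound 4 (0.92 log units; beyond the scatter), so on the core of compound 3 this change clearly weakens inhibition. Compound 2 gives < 2000 nM, which is a limit of the assay and not a number, so the step on the core of compound 1 cannot be read and the two steps cannot be set side by side: the limit of < 2000 nM in this assay, at which 1 of the 4 values shown sits. For the compounds shown here, the change also sits on a different ring in each pair, so the single readable step shows what happens in one setting only and does not show whether the same penalty, or any penalty, carries from one core to the other.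

Open, on these data alone, is how hydrogen, chloro, methoxy or nitrile on that same aromatic carbon would compare with fluoro and trifluoromethyl on the core of compound 3, which would show whether the step belongs to trifluoromethyl alone or follows a wider trend. Also open, as far as these compounds go, is whether an amide in place of the carboxylic acid would keep any of this activity on either core.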